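Swapping a tert-butyl for a furan on an amide

The source may report more compounds than this note shows. Statements on the series, on what has been measured and on what is new or still open speak of the compounds shown alone.

Compound 1 `CC(C)(C)C(=O)Nc1nc(C2CC2)cs1` is, in an assay on CHO cells for displacement of a labelled ligand from adenosine receptor A1 (Homo sapiens), read by fluorescence, with a stated time of 1 h (a higher number here means a weaker inhibitor, a lower number a stronger inhibitor), the weaker of the two measured compounds: compound 1 gives 12300 nM, while compound 2 `O=C(Nc1ccc2[nH]ncc2c1)c1ccc[nH]1` gives 3160 nM. The unmeasured compound 3 `O=C(Nc1nc(C2CC2)cs1)c1ccoc1` keeps the core of compound 1 and changes only the group on the carbonyl carbon (furan-3-yl in place of tert-butyl on a carbonyl carbon). For the measured compounds named here, with no measured pair showing this exact change, the size of the step is uncertain. The step of a 2.1-fold lower number from compound 1 to compound 3 (0.31 log units; beyond the scatter) is expected to be small, toward a stronger inhibitor, near the edge of the scatter. Compound 3 is therefore estimated at 6000 nM, within a range of 2000 nM to 20000 nM.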

Compound 3, inhibition constant: 2950 nM
The estimate for compound 3 lay 2.0-fold (0.31 log units) above the measured number; the range from low to high includes it.
By their numbers in this assay, from the lowest: compounds 3 and 2 (each within the scatter of the next); then compound 1.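

At the carbonyl carbon of the amide in compound 1, the group can be changed with a real effect on the number: in this assay, putting furan-3-yl in place of tert-butyl gives a 4.2-fold lower number from compound 1 to compound 3 (0.62 log units; beyond the scatter). This single change brings in a five-membered aromatic ring and a hydrogen-bond acceptor together, so the pair cannot separate the two. No measurement shown accounts for the step.

Going by these compounds, it remains open whether the furan oxygen matters, and whether a phenyl ring or a furan-2-yl group at this place would give a similar number. Compound 2 differs from compound 3 in more than one place, so it cannot settle this.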